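The source may hold more compounds than are shown below. What is called first, only, known or untested is meant among the compounds shown, and "the series" means these compounds.

In an in vitro ADME assay on microsomes from liver (Rattus norvegicus) for metabolic stability (on this read-out higher numbers stand for fast clearance and lower numbers for slow clearance), compound 1 `Nc1nccc(Nc2ccc(Oc3ccc(Cl)cc3)cc2)n1` gives 41 mL.min-1.g-1. Compound 2 `Nc1ccnc(Nc2ccc(Oc3ccc(Cl)cc3)cc2)c1` gives > 399 mL.min-1.g-1, which is a limit of the assay and not a number, and it stands at the fast-clearance end of the two values. Compound 3 `Nc1cnnc(Nc2ccc(Oc3ccc(Cl)cc3)cc2)c1` carries 5-aminopyridazin-3-yl in place of 4-aminopyridin-2-yl on a nitrogen on an aromatic ring. Within the data shown here, the only measured step, an at least 9.7-fold higher number from compound 1 to compound 2 (0.98 log units; beyond the scatter), lies beyond the scatter. The new ring resembles that of compound 1 more closely, so a return toward slower clearance seems likely. A step of an at least 6.6-fold lower number from compound 2 to compound 3 (0.82 log units; beyond the scatter) is therefore expected. For compound 3 the estimated value is 60 mL.min-1.g-1, with an expected range of 20 mL.min-1.g-1 to 200 mL.min-1.g-1.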

Compound 3, intrinsic clearance in microsomes: > 399 mL.min-1.g-1
Compound 3 ended at the assay's limit; the forecaster's own chance of this, stated with the estimate: 8%; at least 6.6-fold (0.82 log units) between middle value and limit.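

In this assay there is an at least 9.7-fold higher number from compound 1 to compound 3 (0.98 log units; beyond the scatter), so 5-aminopyridazin-3-yl, like 4-aminopyridin-2-yl before it, does not keep the number of compound 1. One more hetero atom in the ring on this nitrogen therefore does not, by itself, bring the read-out back into the measurable range. Compound 2 and compound 3 both end at a limit of the assay and not at a number, so the step between them cannot be read: the limit of > 399 mL.min-1.g-1 in this assay, at which 2 of the 3 values shown sit.

On these data alone, how far compound 2 and compound 3 truly differ stays open. So does whether 2-aminopyrimidin-4-yl carrying an added methyl group would keep a readable clearance.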